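This account rests on a few compounds, and the source may have more. Where it says the series, first, only, none or still open, it means among the compounds named here.

Measured so far:
- compound 2 `CC(C)=CC(=O)Nc1cc2c(N3CCCc4ccccc43)ncnc2cc1O[C@@H]1CCOC1`: 7910 nM
- compound 1 `CC/C=C/C(=O)Nc1cc2c(N3CCc4ccccc43)ncnc2cc1O[C@@H]1CCOC1`: 10900 nM

Both compounds were tested in a functional assay on A549 cells (Homo sapiens) for antiproliferative activity, read by MTT assay, with a stated time of 72 h; a higher number here means a weaker inhibitor, a lower number a stronger inhibitor. Compound 2 gives 7910 nM and compound 1 gives 10900 nM. Compound 2 stands alongside compound 1 on these numbers: the two values lie within the usual scatter of each other, so neither can be called the stronger inhibitor, and both sit in the weak range.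

Compound 3 `CC/C=C/C(=O)Nc1cc2c(N3CCCc4ccccc43)ncnc2cc1O[C@@H]1CCOC1` is not yet measured. It differs from compound 2 in a single place, described by but-1-en-1-yl in place of 2-methylprop-1-en-1-yl on a carbonyl carbon. The group that enters is the same one that compound 1 carries, while the core of compound 3 is that of compound 2. For the measured compounds named here, since the two measured compounds differ in two places at once, no single step is available that isolates this change, and the two values together show no difference beyond the scatter.

For compound 3 the step from compound 2 is expected to be a 1.1-fold higher number from compound 2 to compound 3 (0.06 log units; within the scatter), in no clear direction. Compound 3 is therefore estimated at 9000 nM, within a range from 3000 nM to 27000 nM.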

Compound 3, half-maximal inhibitory concentration: 14100 nM
Compound 3: the middle estimate sits 1.6-fold (0.19 log units) below what was measured, within the range that was stated.
By their numbers in this assay, from the lowest: compounds 2, 1 and 3 (each within the scatter of the next).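

For the compounds shown here, compound 3 gives the first comparisons in which only one place differs. In this assay, but-1-en-1-yl in place of 2-methylprop-1-en-1-yl on the carbonyl carbon gives a 1.8-fold higher number from compound 2 to compound 3 (0.25 log units; within the scatter), so these two unbranched and branched chains of equal carbon count cannot be told apart at this position. The other place can now be read alone as well: 1,2,3,4-tetrahydroquinolin-1-yl in place of 2,3-dihydro-1H-indol-1-yl on the aromatic carbon gives a 1.3-fold higher number from compound 1 to compound 3 (0.11 log units; within the scatter), which again does not separate the two groups, and no measurement at hand offers an explanation for either result.

As far as these compounds go, both groups on the carbonyl carbon are hydrocarbon chains, so it remains open whether a chain ending in an amine, such as a dimethylamino group, would shift the number beyond the scatter. Going by these compounds alone, on the aromatic carbon, only two fused ring groups appear here, which leaves open how a simple amine such as morpholine would compare with them.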